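The compounds below may be only part of what the source reports. "The series", "measured", "known", "first", "only" and "open" are said of these compounds alone.

Among the compounds with values here, in a functional assay on SW-620 cells (Homo sapiens) for cytotoxicity (on this read-out higher numbers stand for weaker inhibition of growth and lower numbers for stronger inhibition of growth), compound 2 (`CSc1ccc(C2=C(c3ccc(F)c(F)c3)C(=O)N3CCCC3C2)cc1`) gives 200 nM and stands lowest of the two numbers so far, with compound 1 (`COc1ccc(C2=C(c3ccc(SC)cc3)CC3CCCN3C2=O)cc1C`) at 500 nM as its only neighbour. Compound 3 (`CSc1ccc(C2=C(c3ccc(C)c(C)c3)C(=O)N3CCCC3C2)cc1`) carries 3,4-dimethylphenyl in place of 3,4-difluorophenyl on a double-bonded ring carbon. Within the data shown here, one measured step bears on this place (a 2.5-fold lower number from compound 1 to compound 2 (0.40 log units; beyond the scatter)), modest and beyond the scatter, with 3,4-difluorophenyl entering in place of 4-methoxy-3-methylphenyl. Among the measured compounds shown here, a similarly modest rise in the number is expected in this assay, though no measured compound carries 3,4-dimethylphenyl. Compound 3 is estimated at 320 nM (expected range 130 nM to 800 nM), which gives an expected step (a 1.6-fold higher number from compound 2 to compound 3 (0.20 log units; within the scatter)).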

Compound 3, concentration for 50% growth inhibition: 700 nM
Beside the measured number, compound 3's estimate is 2.2-fold (0.34 log units) below it; measured number inside the range.
By their numbers in this assay, from the lowest: compound 2; then compounds 1 and 3 (each within the scatter of the next).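

In this assay 3,4-dimethylphenyl in place of 3,4-difluorophenyl gives a step beyond the scatter (a 3.5-fold higher number from compound 2 to compound 3 (0.54 log units; beyond the scatter)), so this position separates two groups that match in heavy-atom count and carry no hydrogen-bond donors or acceptors. Methyl in place of methoxy on an aromatic carbon stays within the scatter (a 1.4-fold higher number from compound 1 to compound 3 (0.15 log units; within the scatter)), so 4-methoxy-3-methylphenyl and 3,4-dimethylphenyl are not told apart here. No evidence on hand accounts for either step. Open, as far as these compounds go, is how a single fluorine, a carboxylic acid or an amine on this aromatic ring would read at this position.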